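This account rests on a few compounds, and the source may have more. Where it says the series, first, only, none or still open, it means among the compounds named here.

Measured in a functional assay on SH-SY5Y cells (Homo sapiens) for cytotoxicity, read by MTT assay, with a stated time of 56 h; a lower number here means that less compound is needed, a higher number that more compound is needed for the effect:
- compound 1 `c1ccc(-c2ccccc2OCCCCCCCCn2cc(-c3cccnc3)nn2)cc1`: 8.2 nM
- compound 2 `O=C(NCCCCCCCCn1cc(-c2cccnc2)nn1)Nc1ccccc1-c1ccccc1`: 154 nM
- compound 3 `O=S(=O)(NCCCCCCn1cc(-c2cccnc2)nn1)c1ccccc1Br`: 175 nM

Compound 3, at 175 nM, cannot be told apart from compound 2, at 154 nM, while compound 1, at 8.2 nM, needs clearly less compound than either. Compound 4 `O=S(=O)(NCCCCCCn1cc(-c2cccnc2)nn1)c1ccccc1-c1ccccc1` has phenyl in place of bromo on an aromatic carbon, ortho to a large group: phenyl in place of bromo on an aromatic carbon. Compound 1 and compound 2 also carry a phenyl on an aromatic ring, but they differ from compound 3 in other places too, so they offer only a loose guide. For the measured compounds named here, no measured pair isolates this change. A modest move towards a lower number is expected, a 2.5-fold lower number from compound 3 to compound 4 (0.40 log units; beyond the scatter). For compound 4 the estimated value is 70 nM, with an expected range of 15 nM to 300 nM.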

Compound 4, half-maximal effective concentration: 100 nM
The estimate for compound 4 lay 1.4-fold (0.15 log units) below the measured number; the range from low to high includes it.
By their numbers in this assay, from the lowest: compound 1; then compounds 4, 2 and 3 (each within the scatter of the next).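

Swapping bromo for phenyl on this aromatic carbon, ortho to a large group, gives in this assay (a 1.8-fold lower number from compound 3 to compound 4 (0.24 log units; within the scatter)), so compound 3 and compound 4 cannot be told apart. At this position, then, a single bromine and a six-carbon aromatic ring give numbers that lie within the scatter of each other. Nothing available explains this result. On these data alone, whether an amine or a carboxylic acid at the same carbon would give a clearly different number remains open. So does whether the same swap would give a similar result on the core of compound 1.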